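This account rests on a few compounds, and the source may have more. Where it says the series, first, only, none or still open, it means among the compounds named here.

Measured compounds in a physicochemical assay for solubility, in phosphate buffer, measured as kinetic solubility, at pH 7.4; on this read-out higher numbers stand for higher solubility and lower numbers for lower solubility:
- compound 1 `Cc1ccccc1-c1nc(CN2CCC(C(=O)NCCCN3CCCC(C(C)C)C3)CC2)c(C)o1`: > 71 ug/mL
- compound 2 `Cc1ccccc1-c1nc(CN2CCC(C(=O)N3CCN(C4CCN(C)CC4)CC3)CC2)c(C)o1`: > 71 ug/mL
- compound 3 `Cc1cccc(-c2nc(CN3CCC(C(=O)NCCCN4C[C@H](C)C[C@H](C)C4)CC3)c(C)o2)c1`: > 69 ug/mL

All three values are limits of this assay, not numbers. The value of compound 3 sits at the limit of > 69 ug/mL in this assay, at which 1 of the 3 values shown sits. Compounds 1 and 2 sit at the limit of > 71 ug/mL in this assay, at which 2 of the 3 values shown sit. Among the compounds with values here, no compound in the set has a value below either limit, so compound 3 cannot be ranked against the others beyond saying it sits at the ceiling like them.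

Compound 4 `COc1ccc(-c2nc(CN3CCC(C(=O)NCCCN4C[C@H](C)C[C@H](C)C4)CC3)c(C)o2)cc1OC` is the next compound. Its change from compound 3 is 3,4-dimethoxyphenyl in place of 3-methylphenyl on an aromatic carbon.

Within the data shown here, no measured step is available in this assay. The expected step that the limit leaves unreadable from compound 3 to compound 4 is none beyond the scatter, with the measurement likely again returning a limit. Compound 4 is estimated at 70 ug/mL, ranging from 40 ug/mL to 110 ug/mL.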

Compound 4, solubility: > 76 ug/mL
Compound 4: a limit, no number (the forecaster's own chance of this, stated with the estimate: 70%); middle value at least 1.0-fold (0.03 log units) away from the limit.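

In this assay compound 3 and compound 4 both return limits rather than numbers, so the step between them cannot be read. The compounds shown leave open what actual solubility values lie beyond these limits.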